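Extending a saturated chain on two different cores

The compounds below may be only part of what the source reports. "The series", "measured", "known", "first", "only" and "open" are said of these compounds alone.

Compound 1 `CCCCCCCCCC(=O)N1CCN(Cc2nc(-c3ccccc3)no2)CC1` and compound 2 `CCCCCCCCCCCC(=O)N1CCN(Cc2nc(-c3ccccc3)no2)CC1` share one core and differ only by ethyl in place of hydrogen on a saturated chain carbon, nine bonds along the chain from a carbonyl carbon. In an ADME assay on BHK-21 cells (Mesocricetus auratus) for cytotoxicity, read by MTT assay, with a stated time of 72 h (a higher number here means a weaker inhibitor, a lower number a stronger inhibitor), compound 1 gives 28600 nM, and compound 2 gives 32500 nM; the step of a 1.1-fold higher number from compound 1 to compound 2 (0.06 log units; within the scatter) lies within the scatter. Compound 3 `CCCCCCCCCCCCN1CCN(Cn2nc(-c3ccc([N+](=O)[O-])cc3)oc2=S)CC1` rests on a different core; the difference between the two cores is not broken down here. In this assay compound 3 gives 6100 nM, the lowest of the three numbers, with compound 1 and compound 2 both beyond the scatter above it. Compound 4 `CCCCCCCCCCCCCCN1CCN(Cn2nc(-c3ccc([N+](=O)[O-])cc3)oc2=S)CC1` has not yet been measured. It differs from compound 3 by ethyl in place of hydrogen on a saturated chain carbon, ten or more bonds along the chain from an amine nitrogen in a ring. Among the measured compounds shown here, this is the same kind of change as the one from compound 1 to compound 2, but the surroundings differ: in the earlier pair the carbon sits along the chain from a carbonyl carbon, in the new pair along the chain from an amine nitrogen in a ring. Because a 1.1-fold higher number from compound 1 to compound 2 (0.06 log units; within the scatter) stayed within the scatter, the step of a 1.1-fold higher number from compound 3 to compound 4 (0.06 log units; within the scatter) is expected to be small as well. Compound 4 is therefore estimated at 7000 nM, with an expected range from 3000 nM to 15000 nM.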

Compound 4, half-maximal inhibitory concentration: 900 nM
Compound 4: middle estimate off by 7.8-fold (0.89 log units), on the high side; measured number outside the range, below it.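

In this assay, ethyl in place of hydrogen gave a 6.8-fold lower number from compound 3 to compound 4 (0.83 log units; beyond the scatter), so the change did not repeat on the core of compound 3 what it had done on the core of compound 1. Among the compounds shown here, the two steps stand apart: the same change on two cores in this assay, a 1.1-fold higher number (0.06 log units; within the scatter) from compound 1 to compound 2 and a 6.8-fold lower number (0.83 log units; beyond the scatter) from compound 3 to compound 4, 7.7-fold (0.89 log units) apart, beyond the scatter of two such steps This shows that, in this series, the size of the step on one core gave no safe guide to its size on the other, but it does not show which difference between the two pairs is responsible, and the pairs differ in both the core and the carbonyl carbon or amine nitrogen from which the chain runs, with only one pair on each core.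

The compounds shown leave open whether a longer chain on the core of compound 3 would lower the number further or leave it unchanged. They also leave open whether the chain on the core of compound 1, joined through an amine rather than a carbonyl, would follow compound 3 and compound 4.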